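A few compounds are considered here, and "the series" means these few. Any claim that something is new, unique, unknown or untested is made for them only; others in the source may bear on it.

Compound 1 `COc1cc(OC)c(OC)cc1/C=C/C(=O)c1cc(OC(C)=O)ccc1OC(C)=O`: 2.37 ug/mL
Compound 2 `COc1cc(OC)c(OC)cc1/C=C/C(=O)c1ccccc1`: 2.01 ug/mL
Compound 3 `COc1cc(OC)c(OC)cc1/C=C/C(=O)c1cccc(C(F)(F)F)c1`: 2.09 ug/mL

In a functional assay, read by Griess assay, with a stated time of 2.5 h (a higher number here means a weaker inhibitor, a lower number a stronger inhibitor), compound 2 stands at 2.01 ug/mL, within the scatter of the other two compounds. Compound 4 `COc1cc(OC)c(OC)cc1/C=C/C(=O)c1ccc(O)cc1` differs from compound 2 by hydroxy in place of hydrogen on an aromatic carbon, or phenyl to 4-hydroxyphenyl. For the measured compounds named here, the only measured step of this kind, a 1.0-fold higher number from compound 2 to compound 3 (0.02 log units; within the scatter), brings in trifluoromethyl rather than hydroxy, so it bears on this change only loosely. From the compounds shown here alone, no shift beyond the scatter is therefore expected, and the direction remains open. The expected step is a 1.0-fold higher number from compound 2 to compound 4 (0.02 log units; within the scatter). Compound 4 is estimated at 2.1 ug/mL, with an expected range from 1.1 ug/mL to 4 ug/mL.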

Compound 4, half-maximal inhibitory concentration: 2.5 ug/mL
For compound 4 the middle estimate is 1.2-fold (0.08 log units) below the measured one; low and high end bracket the measured number.
By their numbers in this assay, from the lowest: compounds 2, 3, 1 and 4 (each within the scatter of the next).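

In this assay hydroxy in place of hydrogen on the aromatic carbon para to a large group gives a 1.2-fold higher number from compound 2 to compound 4 (0.09 log units; within the scatter) and so leaves the number within the scatter. This extends the earlier picture, which held only a trifluoromethyl step, to a group carrying a hydrogen-bond donor and acceptor. No available evidence bears on this result.

From the compounds shown here alone, whether an amine or a carboxylic acid at this place would move the number beyond the scatter remains open. A longer chain there is equally untested among the compounds shown.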